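The source may report more compounds than this note shows. Statements on the series, on what has been measured and on what is new or still open speak of the compounds shown alone.

Compound 1 `CCN1CCN(c2cc(C)c3cc(NC(=O)c4ccc(C)cc4)ccc3n2)CC1` was tested in a functional assay on MCF7 cells (Homo sapiens) for antiproliferative activity, read by MTT assay, with a stated time of 72 h (a lower number here means a stronger inhibitor, a higher number a weaker inhibitor), where compound 1 gives 6740 nM. Going by the values given here, only one other compound has a number here: compound 2 `CCNc1cc(C)c2cc(NC(=O)c3ccc(Cl)c(Cl)c3)ccc2n1`, which differs from compound 1 in more than one place; in this assay compound 2 gives 48600 nM, a gap beyond the usual scatter, so compound 1 holds the lower of the two numbers. Compound 3 `CCN1CCN(c2cc(C)c3cc(NC(=O)c4ccc(Cl)cc4)ccc3n2)CC1` has not yet been measured. Compared with compound 1, the change is chloro in place of methyl on an aromatic carbon. Among the compounds with values here, no pair of measured compounds differs only at this spot, so nothing beyond the small size of the change itself guides the expectation. The expected step in this assay is a 1.3-fold lower number from compound 1 to compound 3 (0.13 log units; within the scatter), small enough to sit within the scatter or just beyond it, leaning slightly toward a stronger inhibitor. Compound 3 is therefore estimated at 5000 nM, with a range from 2000 nM to 15000 nM.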

Compound 3, half-maximal inhibitory concentration: 1530 nM
Beside the measured number, compound 3's estimate is 3.3-fold (0.51 log units) above it; measured number below the stated range.
By their numbers in this assay, from the lowest: compound 3; then compound 1; then compound 2.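

Going by these compounds alone, this is the first pair in this assay that differs in one place only, so this spot can now be read on its own: the step is a 4.4-fold lower number from compound 1 to compound 3 (0.64 log units; beyond the scatter) when chloro takes the place of methyl on the aromatic carbon para to the large group. Exchanging one heavy atom for another, with no ring, hydrogen-bond donor, hydrogen-bond acceptor or net charge entering or leaving, is thus enough to move the number beyond the usual scatter, so what sits at this position matters in this assay. Nothing measured for these compounds explains why the step has this direction or size.

One pair cannot show how other groups at this spot, such as fluoro, methoxy or a longer chain like ethyl, would compare with chloro. It also leaves open whether the same exchange would give a similar step if a different amine were attached to the shared core.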